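This account rests on a few compounds, and the source may have more. Where it says the series, first, only, none or still open, it means among the compounds named here.

Measured in a functional assay on HT-29 cells (Homo sapiens) for antiproliferative activity, read by MTT assay, with a stated time of 72 h; on this read-out higher numbers stand for weaker inhibition and lower numbers for stronger inhibition:
- compound 1 `Cn1ccc2c(Oc3ccc(NC(=O)c4cc5cccnc5n(-c5ccc(F)cc5)c4=O)cc3)ccnc21` gives 250 nM
- compound 2 `COc1ccc(-n2c(=O)c(C(=O)Nc3ccc(Oc4ccnc5c4ccn5C)cc3)cc3cccnc32)cc1` gives 2050 nM
- compound 3 `Cn1ccc2c(Oc3ccc(NC(=O)c4cc5cccnc5n(-c5ccc(Br)cc5F)c4=O)cc3)ccnc21` gives 2580 nM

Compound 2 stands second highest of the three numbers in this assay: its nearest neighbour is compound 3, with a 1.3-fold higher number from compound 2 to compound 3 (0.10 log units; within the scatter), and its furthest is compound 1, with an 8.2-fold higher number from compound 1 to compound 2 (0.91 log units; beyond the scatter). All three compounds share the same core and differ only in the aryl group on the ring nitrogen; the two steps away from compound 1, an 8.2-fold higher number from compound 1 to compound 2 (0.91 log units; beyond the scatter) and a 10-fold higher number from compound 1 to compound 3 (1.01 log units; beyond the scatter), are the only ones beyond the scatter.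

Compound 4 `COc1ccc(-n2c(=O)c(C(=O)Nc3ccc(Oc4ccnc5c4ccn5C)c(F)c3)cc3cccnc32)cc1` is the next compound in the series. The change from compound 2 is fluoro in place of hydrogen on an aromatic carbon. For the measured compounds named here, none of the measured steps touches this ring; every one of them alters the aryl group on the ring nitrogen, so nothing measured bears directly on this change. Going by the values given here, with no precedent, the expectation is a step within the scatter in this assay, in no preferred direction, and the estimated step is a 1.0-fold lower number from compound 2 to compound 4 (0.01 log units; within the scatter). Compound 4 is therefore expected to give about 2000 nM in this assay, within a range of 700 nM to 6000 nM.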

Compound 4, half-maximal inhibitory concentration: 1290 nM
The estimate for compound 4 lay 1.6-fold (0.19 log units) above the measured number; the range from low to high includes it.
By their numbers in this assay, from the lowest: compound 1; then compounds 4, 2 and 3 (each within the scatter of the next).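

The only step shown outside the aryl group on the ring nitrogen is fluoro in place of hydrogen on an aromatic carbon, ortho to a large group and meta to a large group. In this assay it gives a 1.6-fold lower number from compound 2 to compound 4 (0.20 log units; within the scatter), so with the 4-methoxyphenyl group on the ring nitrogen, this position accepts fluoro without a change that can be told from the scatter, and compound 2 and compound 4 cannot be ordered. Nothing at hand accounts for this result.

From the compounds shown here alone, it remains open whether fluoro at this position would also leave the number unmoved with the 4-fluorophenyl group of compound 1 on the ring nitrogen, where the number is lowest. Going by these compounds, it is also open how a larger group here, such as chloro, methyl or methoxy, or an amine, would read out.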